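The compounds below may be only part of what the source reports. "The series", "measured", "known", "first", "only" and "open" are said of these compounds alone.

Series notes. The shared core carries a butylamino group and an amino group on the aromatic part and a ring amine nitrogen that takes the variable group. Within the data shown here, compound 1 `CCCCNc1nc(N)nc2c1CN(S(C)(=O)=O)CC2` gives in an assay on HEK293 cells for agonist activity at Toll-like receptor 8 (Homo sapiens), read by a luciferase reporter, with a stated time of 6 h (on this read-out lower numbers stand for an effect already at smaller amounts and higher numbers for an effect only at larger amounts of compound), a value of 9.9 uM and stands as the higher of the two numbers measured so far. Compound 2 `CCCCNc1nc(N)nc2c1CN(Cc1ccc(C(C)(C)C)cc1)CC2` gives in this assay a value of 0.66 uM, and the gap between compound 1 and compound 2 lies beyond the scatter. Compound 3 `CCCCNc1nc(N)nc2c1CN(C(=O)c1ccncc1)CC2` has not yet been measured. It differs from compound 1 by (pyridin-4-yl)carbonyl in place of methylsulfonyl on an amine nitrogen in a ring. Among the measured compounds shown here, no measured step covers this change. The step of a 3.0-fold lower number from compound 1 to compound 3 (0.48 log units; beyond the scatter) is expected to be a moderate decrease of the number, beyond the scatter. For compound 3 a value of 3.3 uM is estimated, in the range 0.8 uM to 12 uM.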

Compound 3, minimum effective concentration: > 25 uM
Compound 3: only a limit was reported; the forecaster's own chance of this, stated with the estimate: 10%; middle value at least 7.5-fold (0.87 log units) from the limit.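

On the amine nitrogen in the ring, (pyridin-4-yl)carbonyl in place of methylsulfonyl gives an at least 2.5-fold higher number from compound 1 to compound 3 (0.40 log units; beyond the scatter) in this assay. An aromatic ring in the group on this nitrogen therefore does not by itself bring a low number, although compound 2 also carries one and gives 0.66 uM. Compound 3 gives a limit, not a number: the limit of > 25 uM in this assay, at which 1 of the 3 values shown sits.

Still open, going by these compounds, is whether the rise goes with the carbonyl or with the pyridine ring. A benzoyl group or a pyridin-4-ylmethyl group on the same nitrogen would separate the two.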